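The source may hold more compounds than are shown below. What is called first, only, known or untested is meant among the compounds shown, and "the series" means these compounds.

Working notes on the series, step from compound 3 to compound 4.

Three compounds have been put through an ADME assay on MRC5 cells (Homo sapiens) for cytotoxicity, read by WST assay, with a stated time of 48 h (a higher number here means a weaker inhibitor, a lower number a stronger inhibitor), so far. Compound 1, `CC(C)C[C@]1(O)NC(=O)[C@]2(OC(Cc3ccccc3)=CC2=O)[C@H]1O`, returns only a limit in this assay, > 50000 nM. Compound 2, `Cc1cc2c(c(=O)[nH]1)OC(C(=O)CC(C)C)O2`, likewise returns only a limit in this assay, > 50000 nM. Compound 3, `CC1=CC(=O)[C@]2(O[C@@H]2C(=O)CC(C)C)C(=O)N1`, has no result in this assay, recorded as "not determined" (no result reported). Going by the values given here, compound 3 therefore stands nowhere on the numbers: the only two values that exist are limits, (the limit of > 50000 nM in this assay, at which 2 of the 3 values shown sit), and no number at all is attached to compound 3.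

Compound 4 is `CC1=CC(=O)C2(OC2C(=O)CC(C)C)C(=O)N1`. The change from compound 3 to compound 4 is the two compounds have the same atoms and bonds; at least one stereo element is drawn with a configuration in one of them and without one in the other: 2 of 2 stereo elements differ; a stereocentre at a saturated ring carbon is drawn S in compound 3 and without a configuration in compound 4; a stereocentre at a saturated ring carbon is drawn S in compound 3 and without a configuration in compound 4. Among the compounds with values here, no step between measured compounds exists against which this change could be gauged. Since the atoms and bonds are unchanged and only the drawing of configuration at two ring carbons is absent in compound 4, no step beyond the usual scatter in this assay is expected in either direction.

The expectation for compound 4 in this assay is that it will behave as the two measured compounds do because of the limit of > 50000 nM in this assay, at which 2 of the 3 values shown sit, and it is estimated at 70000 nM, with a range from 20000 nM to 250000 nM, most probably reported as a limit rather than a number.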

Compound 4, half-maximal inhibitory concentration: 33200 nM
Beside the measured number, compound 4's estimate is 2.1-fold (0.32 log units) above it; measured number inside the range.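

Going by these compounds alone, no step from compound 3 to compound 4 can be read in this assay: compound 3 has no number there, while compound 4 gives 33200 nM. The compounds shown leave open whether drawing the two ring carbons with a defined configuration, as in compound 3, rather than without one, as in compound 4, goes with any difference in this read-out.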